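Trifluoromethoxy in place of trifluoromethyl, compound 3 to compound 4

This account rests on a few compounds, and the source may have more. Where it says the series, first, only, none or still open, it means among the compounds named here.

Compound 1 `O=C(Nc1nc2ccc(F)cc2s1)N1CCN(c2ccc(Cl)nn2)CC1` gives in an assay on HEK293 cells for inhibition of transient receptor potential cation channel subfamily V member 1 (Homo sapiens), read by FLIPR, at pH 5.5 (on this read-out lower numbers stand for stronger inhibition and higher numbers for weaker inhibition), only the assay limit > 10000 nM. Compound 2 `Cc1ccc(N2CCN(C(=O)Nc3ccc(C(C)C)cc3)CC2)nn1` likewise returns only the limit > 10000 nM. Compound 3 `Cc1ccc(N2CCN(C(=O)Nc3ccc(C(F)(F)F)cc3)CC2)nn1` also stops at the limit > 10000 nM. The step that the two limits leave unreadable from compound 2 to compound 3 is therefore unreadable, and compound 3 stands at the limit of > 10000 nM in this assay, at which 3 of the 3 values shown sit; no value in the series is a number. Compound 4 `Cc1ccc(N2CCN(C(=O)Nc3ccc(OC(F)(F)F)cc3)CC2)nn1` differs by trifluoromethoxy in place of trifluoromethyl on an aromatic carbon. Going by the values given here, no measured step bears on this change, all three values being limits; no shift beyond the scatter is expected in either direction. Compound 4 is estimated at 15000 nM, within 3000 nM to 50000 nM, most probably again reported as a limit. The expected step that the limit leaves unreadable from compound 3 to compound 4 is correspondingly small.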

Compound 4, half-maximal inhibitory concentration: > 10000 nM
Compound 4: a limit, no number; the forecaster's own chance of this, stated with the estimate: 75%; the middle value is on the limit's open side.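

Going by these compounds alone, compound 4 gives only a limit, as do compound 2 and compound 3, so no step among them can be read: the limit of > 10000 nM in this assay, at which 4 of the 4 values shown sit.

The compounds shown leave open whether trifluoromethoxy, trifluoromethyl and isopropyl differ at all in inhibition.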